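Series notes: acetyl for dimethylamino on the outer phenyl

A few compounds are considered here, and "the series" means these few. Any claim that something is new, unique, unknown or untested is made for them only; others in the source may bear on it.

Measured so far:
- compound 1 `COc1cc(C)cc(-c2c(-c3ccnc(-c4ccc(N(C)C)cc4)c3)cnn2CC#N)c1`: 88%
- compound 2 `COc1cc(C)cc(-c2nn(CC#N)cc2-c2ccnc(-c3ccc(N(C)C)cc3)c2)c1`: 95%
- compound 3 `COc1cc(C)cc(-c2nn(CC#N)cc2-c2ccc(-c3cccc(C(C)=O)c3)nc2)c1`: 82%

Three compounds on a shared core have been run in a functional assay on SNB-75 cells (Homo sapiens) for cytotoxicity, read by sulforhodamine B assay, with a stated time of 48 h, tested at 0.001 uM; on this read-out lower numbers stand for a stronger effect and higher numbers for a weaker effect at the one concentration tested. Compound 1 gives 88% in this assay, the middle number of the three. Going by the values given here, its nearest neighbour is compound 3, whose value sits a few points lower, and the furthest is compound 2, a few points higher; both gaps are within the usual scatter, so no compound of the three can be told apart from the others on this read-out. Among the compounds with values here, no single-point step between measured compounds is available.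

Compound 4 `COc1cc(C)cc(-c2c(-c3ccnc(-c4ccc(C(C)=O)cc4)c3)cnn2CC#N)c1` is the next one to be measured. Relative to compound 1 the change is acetyl in place of dimethylamino on an aromatic carbon. Compound 3 already carries an acetyl, on a different phenyl, and gives 82%, which gives no sign of a large shift. The step from compound 1 to compound 4 in this assay is therefore expected to be small, a number 2 percentage points lower from compound 1 to compound 4 (within the scatter), not beyond the scatter. For compound 4 the expected value is 86%, in a range of 70% to 100%.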

Compound 4, a percentage reported as activity, at one concentration (the size of the read-out at that concentration, not a potency): 80%
The estimate for compound 4 lay 6 percentage points above the measured number; the range from low to high includes it.
By their numbers in this assay, from the lowest: compounds 4, 3, 1 and 2 (each within the scatter of the next, the first and the last beyond it).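

Acetyl in place of dimethylamino, read as 4-(dimethylamino)phenyl to 4-acetylphenyl, gives the first single-place step in the series: in this assay, a number 8 percentage points lower from compound 1 to compound 4 (within the scatter). At the one concentration tested, this swap on the outer phenyl therefore leaves no difference that can be told from the scatter, so the two groups cannot be separated on this read-out. No measurement shown accounts for this step or for its size.

On these data alone, whether a carboxylic acid, a primary amine or a morpholine at this place would give a step beyond the scatter remains open. Also open, as far as these compounds go, is whether the same swap would read alike on the core of compound 2, and how these compounds compare at other concentrations.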